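Hydroxymethyl added to the methoxy arm: half-life outlook

The source may report more compounds than this note shows. Statements on the series, on what has been measured and on what is new or still open speak of the compounds shown alone.

Three compounds have numbers in an ADME assay on the whole organism (Rattus norvegicus) for metabolic stability; on this read-out higher numbers stand for a longer-lived compound and lower numbers for a shorter-lived compound. Compound 3 `COc1ccccc1C1C(C(=O)C(C)(C)C)=C(O)C(=O)N1c1ccc(-c2ccon2)cc1` gives 2.6 h and stands highest of the three. Compound 1 `COc1ccc(C(=O)C2=C(O)C(=O)N(c3ccc(-c4ccon4)cc3)C2C2CCCCC2)cn1` gives 1.4 h, which lies within the scatter of compound 3, so no order between these two is claimed. Compound 2 `COc1ccc(C(=O)C2=C(O)C(=O)N(c3ccc(-c4ccon4)cc3)C2c2ccccc2OC)cc1` gives 0.5 h, beyond the scatter below compound 3. Among the measured compounds shown here, the only single-point step among the measured compounds is a 5.2-fold higher number from compound 2 to compound 3 (0.72 log units; beyond the scatter), and it concerns the group on the carbonyl carbon, not the methoxyphenyl side.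

Compound 4 `CC(C)(C)C(=O)C1=C(O)C(=O)N(c2ccc(-c3ccon3)cc2)C1c1ccccc1OCCO` differs from compound 3 by hydroxymethyl in place of hydrogen on a saturated chain carbon bound to an oxygen on an aromatic ring. For the measured compounds named here, no measured step touches this position: the one step in hand changes a different part of the structure, so it gives no direction for the present change. With nothing to support a shift, the step from compound 3 to compound 4 is expected to be a 1.3-fold lower number from compound 3 to compound 4 (0.11 log units; within the scatter), within the scatter. Compound 4 is therefore estimated at 2 h in this assay, with a range from 0.8 h to 5 h.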

Compound 4, half-life: 2.1 h
The estimate for compound 4 lay 1.1-fold (0.02 log units) below the measured number; the measured number falls inside the stated range.
By their numbers in this assay, from the lowest: compound 2; then compounds 1, 4 and 3 (each within the scatter of the next).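

In this assay, 2-(2-hydroxyethoxy)phenyl in place of 2-methoxyphenyl gives a 1.2-fold lower number from compound 3 to compound 4 (0.09 log units; within the scatter), so adding hydroxymethyl on this saturated chain carbon bound to an oxygen on an aromatic ring leaves no readable change in half-life. Among the compounds shown here, this is the first reading at this position, as the earlier step concerned only the group on the carbonyl carbon. Nothing measured here accounts for this result.

Going by these compounds, whether an amine, a carboxylic acid or a longer chain at the same position would also leave the half-life unchanged remains open. Also open, on these data alone, is whether the hydroxymethyl addition would read the same with 4-methoxyphenyl on the carbonyl carbon, as in compound 2 at 0.5 h, rather than with tert-butyl.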